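A few compounds are considered here, and "the series" means these few. Any claim that something is new, unique, unknown or untested is made for them only; others in the source may bear on it.

Compound 1 `Cc1cc2occ(-c3nc(-c4ccccc4)c(-c4ccccc4)n3-c3ccc([N+](=O)[O-])cc3)c(=O)c2cc1Cl`: 25000 nM
Compound 2 `Cc1ccc(-n2c(-c3coc4cc(C)c(Cl)cc4c3=O)nc(-c3ccccc3)c2-c2ccccc2)c(C)c1`: 3120 nM
Compound 3 `Cc1cc2occ(-c3nc(-c4ccccc4)c(-c4ccccc4)n3-c3ccccc3Cl)c(=O)c2cc1Cl`: 6250 nM

These values come from a functional assay on HepG2 cells (Homo sapiens) for inhibition, read by MTT assay, with a stated time of 72 h (on this read-out higher numbers stand for weaker inhibition and lower numbers for stronger inhibition), and the three compounds differ only in the group on an aromatic nitrogen. Two steps show where the last of them stands: a 2.0-fold higher number from compound 2 to compound 3 (0.30 log units; within the scatter), and a 4.0-fold lower number from compound 1 to compound 3 (0.60 log units; beyond the scatter). Its number therefore cannot be told apart from one neighbour but is clearly separated from the other.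

Compound 4 `Cc1cc2occ(-c3nc(-c4ccccc4)c(-c4ccccc4)n3-c3ccc(Br)cc3)c(=O)c2cc1Cl` has not yet been measured. It has 4-bromophenyl in place of 2-chlorophenyl on an aromatic nitrogen.

Going by the values given here, three measured steps concern this same place. The two that replace 4-nitrophenyl, an 8.0-fold lower number from compound 1 to compound 2 (0.90 log units; beyond the scatter) and a 4.0-fold lower number from compound 1 to compound 3 (0.60 log units; beyond the scatter), show that a change here can move the number modestly. The third, a 2.0-fold higher number from compound 2 to compound 3 (0.30 log units; within the scatter), shows that two different groups can give numbers within the scatter of each other. Among the compounds with values here, none of the measured compounds carries 4-bromophenyl, so these steps cannot size the new change directly, and the range must stay wide. No step beyond the scatter is expected, and the estimated change is a 1.3-fold higher number from compound 3 to compound 4 (0.11 log units; within the scatter). For compound 4 the expected value is 8000 nM, with an estimated range of 3000 nM to 25000 nM.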

Compound 4, half-maximal inhibitory concentration: 6250 nM
Compound 4: the middle estimate sits 1.3-fold (0.11 log units) above what was measured; measured number inside the range.
By their numbers in this assay, from the lowest: compounds 2, 3 and 4 (each within the scatter of the next); then compound 1.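

In this assay, the change from the 2-chlorophenyl group to the 4-bromophenyl group gives no change at the digits printed from compound 3 to compound 4 (within the scatter), so on this evidence this position tolerates a swap of both the halogen and its place on the phenyl ring without a readable shift in the number. The new compound also gives a 2.0-fold higher number from compound 2 to compound 4 (0.30 log units; within the scatter), which places three different groups on the aromatic nitrogen within the scatter of one another, while the third comparison with the 4-nitrophenyl compound, a 4.0-fold lower number from compound 1 to compound 4 (0.60 log units; beyond the scatter), confirms that this compound alone stands apart from the others, each of its steps being beyond the scatter. Nothing measured here explains why these three groups read alike or why the 4-nitrophenyl compound differs.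

Since the halogen and its place changed together, 4-chlorophenyl or 2-bromophenyl would be needed to tell those two changes apart. As far as these compounds go, it also remains open whether a plain phenyl group, or a phenyl ring carrying an amine or a carboxylic acid, would stay with compounds 2, 3 and 4 or move away from them.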